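Diaryl sulfoxide series: heteroaryl swap from compound 1 to compound 4

This account rests on a few compounds, and the source may have more. Where it says the series, first, only, none or still open, it means among the compounds named here.

Measured so far:
compound 1 `Cc1scc(C[S+]([O-])C(c2ccccc2)c2ccccc2)c1C` in an assay on HEK293 cells for inhibition of sodium-dependent dopamine transporter (Homo sapiens), read by scintillation counting, with stated times of 5 min and 1 min (a lower number here means a stronger inhibitor, a higher number a weaker inhibitor), gives 284000 nM
compound 2 `Cc1cc(O)nc(C[S+]([O-])C(c2ccccc2)c2ccccc2)n1` gives 109000 nM
compound 3 `[O-][S+](Cc1cccs1)C(c1ccc(F)cc1)c1ccc(F)cc1` gives 4000 nM

Compound 1 carries the highest number of the three; compound 2 is nearest, with a 2.6-fold lower number from compound 1 to compound 2 (0.42 log units; beyond the scatter); compound 3, which differs in more than one place, stands furthest, well beyond the scatter. Compound 4 `[O-][S+](Cc1ccncc1)C(c1ccccc1)c1ccccc1` is the next candidate, changed as pyridin-4-yl in place of 4,5-dimethylthiophen-3-yl on a saturated chain carbon bound to a sulfur. Among the compounds with values here, the one step that bears on it is the exchange of the same group on the same carbon for another nitrogen-containing six-membered aromatic ring, a 2.6-fold lower number from compound 1 to compound 2 (0.42 log units; beyond the scatter), a modest drop. A step of similar size and direction is expected, a 2.6-fold lower number from compound 1 to compound 4 (0.41 log units; beyond the scatter). Compound 4 is therefore estimated at 110000 nM in this assay, within 35000 nM to 330000 nM.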

Compound 4, half-maximal inhibitory concentration: 63500 nM
Compound 4: the middle estimate sits 1.7-fold (0.24 log units) above what was measured; the range from low to high includes it.
By their numbers in this assay, from the lowest: compound 3; then compounds 4 and 2 (each within the scatter of the next); then compound 1.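

On the saturated chain carbon bound to a sulfur, pyridin-4-yl in place of 4,5-dimethylthiophen-3-yl gives a 4.5-fold lower number from compound 1 to compound 4 (0.65 log units; beyond the scatter), a second six-membered nitrogen-containing ring with a lower number than the thiophene. Against 4-hydroxy-6-methylpyrimidin-2-yl, pyridin-4-yl gives a 1.7-fold lower number from compound 2 to compound 4 (0.23 log units; within the scatter), so these two rings cannot be told apart at this place. No data bearing on the reason for either step are available.

Open, as far as these compounds go, is how an amine on the pyridin-4-yl ring or a longer chain at this place would shift the number. Compound 3 differs from compound 4 in more than one place, so which change separates them remains unresolved.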